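A few compounds are considered here, and "the series" means these few. Any claim that something is new, unique, unknown or untested is made for them only; others in the source may bear on it.

Of the compounds shown here, three from one series have been tested in an assay on isolated protein for inhibition of Myeloperoxidase (Homo sapiens), with a stated time of 10 min; a lower number here means a stronger inhibitor, a higher number a weaker inhibitor. Compound 1 `Nc1cc(Cc2ccn(Cc3cccc(-c4ccccc4)c3)n2)c2nn[nH]c2n1` gives 55 nM in this assay. Compound 2 `Nc1cc(C2CCNC3CCC(CC3)COc3cccc(c3)Cn3cc2cn3)c2nn[nH]c2n1` gives 31 nM, and compound 3 `Nc1cc(C2CCNCc3cccc(c3)COc3cccc(c3)Cn3cc2cn3)c2nn[nH]c2n1` gives 25 nM. Among these three, the number for compound 1 sits within the usual scatter of the number for compound 2, so nothing separates those two. The gap from compound 1 to compound 3 lies beyond the scatter, and compound 3 gives the lower number of that pair.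

Compound 4 `Nc1cc(Cc2ccn(Cc3cccc(Oc4ccccc4)c3)n2)c2nn[nH]c2n1` has not yet been measured. It is built from compound 1 by one change: phenoxy in place of phenyl on an aromatic carbon. Going by the values given here, compounds 2 and 3 differ from compound 1 in many places at once, so no single step between measured compounds shows how this kind of swap moves the number. With only the three values to draw on, the expectation is a small step, most likely within the scatter in either direction, namely a 1.1-fold lower number from compound 1 to compound 4 (0.04 log units; within the scatter). Compound 4 is therefore estimated to give 50 nM in this assay, with a range from 20 nM to 140 nM.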

Compound 4, half-maximal inhibitory concentration: 44 nM
Estimate against measurement, compound 4: 1.1-fold (0.06 log units) above, and the stated range covers the measured number.
By their numbers in this assay, from the lowest: compounds 3, 2, 4 and 1 (each within the scatter of the next, the first and the last beyond it).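

In this assay, putting phenoxy in place of phenyl on an aromatic carbon, meta to a large group, gives a 1.3-fold lower number from compound 1 to compound 4 (0.10 log units; within the scatter). Going by these compounds alone, this is the first step that isolates a single change, and it shows that compound 1 and compound 4 cannot be told apart in this assay, even though phenoxy brings one more heavy atom, an oxygen, and a hydrogen-bond acceptor that phenyl lacks. No other measurement is available to explain why the two numbers stay so close.

At this position, the compounds shown carry only these two groups, both with a six-membered aromatic ring of carbon only, so it remains open whether a group of another kind, such as an amine, a carboxylic acid or a longer carbon chain, would move the number beyond the scatter. A single step also leaves open whether the same swap would give a similarly small step on a different carbon of that ring or on a compound with a different core.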